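A pyrrolidin-2-yl swap on compound 1

A few compounds are considered here, and "the series" means these few. Any claim that something is new, unique, unknown or untested is made for them only; others in the source may bear on it.

Compound 1 (`CN[C@@H](C)c1ccc(N2CC[C@H](NS(=O)(=O)c3ccc4cc(Cl)ccc4c3)C2=O)c(F)c1`) stands at a limit and not at a number. In an in vivo ADME assay on the whole organism (strain Sprague-Dawley) for pharmacokinetics, with Rattus norvegicus as the target (a lower number here means that a smaller share of the oral dose reaches the circulation, a higher number that a larger share of the oral dose reaches the circulation), compound 1 gives > 10%, and this is the limit of > 10% in this assay, at which 1 of the 3 values shown sits. Two relatives have true numbers in this assay: compound 2 (`CN(C)[C@H]1CCc2cc(N3CC[C@H](NS(=O)(=O)c4ccc5cc(Cl)ccc5c4)C3=O)ccc21`) gives 61%, and compound 3 (`O=C1[C@@H](NS(=O)(=O)/C=C/c2ccc(Cl)s2)CCN1c1ccc(C2CCCN2)cc1F`) gives 52%. Compound 4 (`O=C1[C@@H](NS(=O)(=O)c2ccc3cc(Cl)ccc3c2)CCN1c1ccc([C@@H]2CCCN2)cc1F`) has not yet been measured. It has pyrrolidin-2-yl in place of 1-(methylamino)ethyl on an aromatic carbon. The expectation rests on two neighbours. One is compound 3, which carries the same pyrrolidin-2-yl group and gives 52%. The other keeps the sulfonyl substituent of compound 1, and that neighbour is compound 2, which gives 61%. Since the starting point is only a limit, the size of the step is uncertain, but the estimated step is upward and is expected to be a step that the limit leaves unreadable from compound 1 to compound 4. Compound 4 is expected to give 50%, with an estimated range from 25% to 70%.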

Compound 4, oral bioavailability: 38%
Compound 4: middle estimate off by 12 percentage points, on the high side; measured number inside the range.
By their numbers in this assay, from the lowest: compound 4; then compounds 3 and 2 (each within the scatter of the next).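

Compound 1 stands only at a limit in this assay, so no step from it to compound 4 can be read: the limit of > 10% in this assay, at which 1 of the 4 values shown sits.

The compounds shown leave open how far, and in which direction, pyrrolidin-2-yl in place of 1-(methylamino)ethyl moves oral bioavailability.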